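This account rests on a few compounds, and the source may have more. Where it says the series, first, only, none or still open, it means among the compounds named here.

Among the measured compounds shown here, compound 2 `Cn1ccnc1SCC(=O)Nc1ccc(-c2nc(-c3ccccc3)c(-c3ccccc3)n2C)cc1` gives 69.4% in a functional assay on HT-29 cells (Homo sapiens) for cytotoxicity, read by MTT assay, with a stated time of 24 h, tested at 80 ug/mL (a higher number here means a stronger effect of the compound at the concentration tested, a lower number a weaker effect), the lowest of the two numbers measured so far; the nearest is compound 1 `Cn1c(-c2ccc(NC(=O)CSc3nc4cc(Cl)ccc4o3)cc2)nc(-c2ccccc2)c1-c1ccccc1`, which gives 79.6%, so that a number 10.2 percentage points lower from compound 1 to compound 2 (beyond the scatter). Compound 3 `Cn1c(-c2ccc(NC(=O)CN3CCN(c4ccccc4)CC3)cc2)nc(-c2ccccc2)c1-c1ccccc1` follows from compound 2 by 4-phenylpiperazin-1-yl in place of (1-methyl-1H-imidazol-2-yl)sulfanyl on a saturated chain carbon bound to a carbonyl carbon. For the measured compounds named here, only the step from compound 1 to compound 2 bears on this change, as it alters the same part of compound 2, and it was modest; compound 3 drops the sulfur altogether, for which no measured precedent exists. The expected step of a number 0.6 percentage points higher from compound 2 to compound 3 (within the scatter) is therefore none beyond the scatter. Compound 3 is estimated at 70%, within 52% to 85%.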

Compound 3, a percentage reported as activity, at one concentration (the size of the read-out at that concentration, not a potency): 63.7%
Estimate against measurement, compound 3: 6.3 percentage points above; measured number inside the range.
By their numbers in this assay, from the lowest: compounds 3 and 2 (each within the scatter of the next); then compound 1.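

In this assay, a group without sulfur can stand on the saturated chain carbon bound to a carbonyl carbon: exchanging (1-methyl-1H-imidazol-2-yl)sulfanyl for the larger 4-phenylpiperazin-1-yl gives a number 5.7 percentage points lower from compound 2 to compound 3 (within the scatter). Against (5-chloro-1,3-benzoxazol-2-yl)sulfanyl, the same group gives a number 15.9 percentage points lower from compound 1 to compound 3 (beyond the scatter), so among these three compounds only compound 1 stands apart. No available evidence explains these differences.

Still open, as far as these compounds go, is whether the phenyl ring of 4-phenylpiperazin-1-yl matters, and a morpholine or an unsubstituted piperazine at this place would test that.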